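Bromo-to-hydrogen step carried from one core to another

This account rests on a few compounds, and the source may have more. Where it says the series, first, only, none or still open, it means among the compounds named here.

Compound 1 `Cc1ccc(N2C(=O)CS/C2=N/N=C/c2c[nH]c3ccc(Br)cc23)cc1`, compound 2 `O=C1CS/C(=N/N=C/c2c[nH]c3ccccc23)N1c1cccc2ccccc12` and compound 3 `O=C1CS/C(=N/N=C/c2c[nH]c3ccc(Br)cc23)N1c1cccc2ccccc12` have been measured in a functional assay on U-251 cells (Homo sapiens) for inhibition, read by spectrophotometry and sulforhodamine B assay, with a stated time of 48 h; a higher number here means a weaker inhibitor of growth, a lower number a stronger inhibitor of growth. In this assay compound 1 gives 54700 nM, compound 2 gives 72500 nM and compound 3 gives 48800 nM; all three numbers lie within the usual scatter of one another. The difference between the core of compound 1 and the core of compound 3 is not broken down here.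

Between compound 3 and compound 2 the change is hydrogen in place of bromo on an aromatic carbon, and it gave a 1.5-fold higher number from compound 3 to compound 2 (0.17 log units; within the scatter).

Compound 4 `Cc1ccc(N2C(=O)CS/C2=N/N=C/c2c[nH]c3ccccc23)cc1` is not yet measured. It arises from compound 1 by the same change, (hydrogen in place of bromo on an aromatic carbon), at a place described in the same words as before. The step from compound 1 to compound 4 in this assay is expected to be a 1.4-fold higher number from compound 1 to compound 4 (0.15 log units; within the scatter), since it rests on the matching step a 1.5-fold higher number from compound 3 to compound 2 (0.17 log units; within the scatter). Compound 4 is therefore estimated at 78000 nM in this assay, with a range from 35000 nM to 170000 nM. Within the data shown here, with only one matched pair to draw on, the expectation is a loose one.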

Compound 4, concentration for 50% growth inhibition: 90200 nM
The estimate for compound 4 lay 1.2-fold (0.06 log units) below the measured number; low and high end bracket the measured number.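

In this assay, hydrogen in place of bromo on the core of compound 1 gives a 1.6-fold higher number from compound 1 to compound 4 (0.22 log units; within the scatter). Set beside the earlier step, the same change shows no difference in size between the two cores: the same change on two cores in this assay, a 1.5-fold higher number (0.17 log units; within the scatter) from compound 3 to compound 2 and a 1.6-fold higher number (0.22 log units; within the scatter) from compound 1 to compound 4, 1.1-fold (0.05 log units) apart, within the scatter of two such steps. Among these compounds, this shows only that the two steps agree; each lies within the scatter on its own, so neither establishes a real effect of the bromo group on growth inhibition, and two cores give no basis for a rule across the series.

The compounds shown leave open whether another group on the same aromatic carbon, such as chloro, methoxy, an amine or a carboxylic acid, would give a step beyond the scatter. Also open, on these data alone, is whether hydrogen in place of bromo would give a matching step on any further core.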